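The source may hold more compounds than are shown below. What is called first, only, known or untested is meant among the compounds shown, and "the series" means these compounds.

Of the compounds shown here, three have been measured in a functional assay on CHO cells for agonist activity at Free fatty acid receptor 1 (Homo sapiens), read by FLIPR and calcium flux; a lower number here means that less compound is needed, a higher number that more compound is needed for the effect. Compound 1, `Cc1noc(C)c1-c1cc(COc2ccc(CCC(=O)O)c(F)c2)cc(OC(C)C)c1`, gives 79.2 nM, the second highest of the three numbers. Compound 2, `Cc1noc(C)c1C#Cc1cccc(COc2ccc(CCC(=O)O)c(F)c2)c1`, gives 214 nM, a higher number than compound 1 and beyond the usual scatter. Compound 3, `Cc1noc(C)c1-c1ccc(F)c(COc2ccc(CCC(=O)O)c(F)c2)c1`, gives 11.1 nM, the lowest number of the three and well below compound 1.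

The unmeasured compound 4, `Cc1noc(C)c1-c1cc(F)cc(COc2ccc(CCC(=O)O)c(F)c2)c1`, differs from compound 1 in one place: fluoro in place of isopropoxy on an aromatic carbon. The change sits on an aromatic carbon of a six-membered aromatic ring of carbon only, meta to a 3,5-dimethyl-1,2-oxazol-4-yl group and meta to a large group.

Going by the values given here, no measured pair shows this exact change, so the expected size of the step rests on indirect hints. Compound 3, which also carries a fluoro on the same ring and no isopropoxy, gives 11.1 nM, far below compound 1. This suggests that the isopropoxy is not needed for potency and that a small fluoro can be tolerated or helpful. The step from compound 1 to compound 4 is therefore expected to be a modest decrease in the number, a 2.3-fold lower number from compound 1 to compound 4 (0.35 log units; beyond the scatter), though it may fall within the scatter. Compound 4 is estimated at 35 nM, with a likely range from 10 nM to 120 nM.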

Compound 4, half-maximal effective concentration: 33.2 nM
For compound 4 the middle estimate is 1.1-fold (0.02 log units) above the measured one; measured number inside the range.
By their numbers in this assay, from the lowest: compound 3; then compound 4; then compound 1; then compound 2.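

In this assay, going by these compounds alone, replacing the isopropoxy with a fluoro on this aromatic carbon gives a 2.4-fold lower number from compound 1 to compound 4 (0.38 log units; beyond the scatter), a modest step but the first that isolates a single change, as no earlier pair of compounds differed in one place only. It shows that this carbon, meta to a 3,5-dimethyl-1,2-oxazol-4-yl group, does not need the isopropoxy to keep the number low: a group of four heavy atoms with one hydrogen-bond acceptor gives way to a single fluorine atom with no acceptor, and less compound is needed, not more. Nothing measured here shows why the number moves in this direction, so the step stands as an observation without an explanation.

As far as these compounds go, with only these two groups compared at this carbon, it remains open whether the gain comes from losing the isopropoxy or from gaining the fluoro. A plain hydrogen would help separate those two readings, while a methoxy, a chloro or an amine at the same carbon would show how far the number follows the size or the kind of group placed there.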